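The source may hold more compounds than are shown below. What is called first, only, known or untested is meant among the compounds shown, and "the series" means these compounds.

Of the compounds shown here, three sharing a core have been measured in a functional assay (blood) for inhibition, with Homo sapiens as the target; on this read-out higher numbers stand for weaker inhibition and lower numbers for stronger inhibition. Compound 1 `OC1O[C@H](CO/N=C2\CCc3cc(Sc4cc(F)cc(C5CCOCC5)c4)ccc32)[C@H](O)[C@H](O)[C@H]1O` carries a sugar attached through an oxygen to a double-bonded nitrogen. In this assay compound 1 gives only a limit, > 2500 nM. One of the three values is such a limit: the limit of > 2500 nM in this assay, at which 1 of the 3 values shown sits. Compound 2 `CCOC(=O)c1csc(CO/N=C(\C)c2ccc(Sc3cc(F)cc(C4CCOCC4)c3)cc2)n1` has an oxygen bearing a (4-(ethoxycarbonyl)-1,3-thiazol-2-yl)methyl group on that nitrogen, and in this assay compound 2 gives 150 nM. Compound 3 `C/C(=N/O)c1ccc(COc2cc(F)cc(C3CCOCC3)c2)cc1` keeps the oxygen bare, and in this assay compound 3 gives 40 nM. Among the two measured numbers, compound 2 therefore has the higher one, and the gap to compound 3 lies beyond the usual scatter.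

Compound 4 `CC(=O)O/N=C(\C)c1ccc(Sc2cc(F)cc(C3CCOCC3)c2)cc1` has not yet been measured. It differs from compound 2 in one place: acetyl in place of (4-(ethoxycarbonyl)-1,3-thiazol-2-yl)methyl on an oxygen. For the measured compounds named here, no measured pair among the three compounds reproduces this change, so its effect is not known from the data. The expectation for the step of a 1.7-fold lower number from compound 2 to compound 4 (0.22 log units; within the scatter) is a modest move toward a lower number, of a size that may not go beyond the scatter. Compound 4 is estimated to give 90 nM in this assay, within a range from 30 nM to 300 nM.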

Compound 4, half-maximal inhibitory concentration: 50 nM
Beside the measured number, compound 4's estimate is 1.8-fold (0.26 log units) above it; the measured number falls inside the stated range.
By their numbers in this assay, from the lowest: compounds 3 and 4 (each within the scatter of the next); then compound 2. At a limit, above all of these: compound 1.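

This is the first comparison among the compounds shown in which only one place changes, so the group on this oxygen can be read on its own. In this assay, replacing (4-(ethoxycarbonyl)-1,3-thiazol-2-yl)methyl with acetyl gives a 3.0-fold lower number from compound 2 to compound 4 (0.48 log units; beyond the scatter) and shows that the group at this position affects the read-out, and that the large group with its five-membered aromatic ring is not needed for a number of this size. The change removes the ring and swaps 11 heavy atoms for 3, but it alters many features at once, and nothing measured here explains why the number falls.

The compounds shown leave open which part of the departing group accounts for the step: the ring, the ester or simply the number of atoms. A methyl group on the same oxygen would test whether the carbonyl of acetyl matters, while a carboxylic acid in place of the ethyl ester would show how a different end on the larger group reads in this assay.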